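Methylsulfanyl for Methoxy on a Rearranged Core

A few compounds are considered here, and "the series" means these few. Any claim that something is new, unique, unknown or untested is made for them only; others in the source may bear on it.

Compound 1 `COc1ccccc1NC(=S)N1CCc2c(sc(NC(=O)c3ccccc3Cl)c2C(N)=O)C1` and compound 3 `COc1ccccc1C(=O)Nc1sc2c(c1C(N)=O)CCN(C(=S)Nc1ccccc1Cl)C2` are built from the same atoms joined differently; how the two cores differ is not broken down here. In a functional assay on HeLa cells (Homo sapiens) for antiproliferative activity, with a stated time of 24 h (a higher number here means a weaker inhibitor, a lower number a stronger inhibitor), compound 1 gives only a limit, > 50000 nM. Compound 3 likewise gives only a limit in this assay, > 50000 nM. Compound 2 `CSc1ccccc1NC(=S)N1CCc2c(sc(NC(=O)c3ccccc3Cl)c2C(N)=O)C1` carries methylsulfanyl in place of methoxy on an aromatic carbon; in this assay compound 2 gives 43600 nM. The step is an at least 1.1-fold lower number from compound 1 to compound 2 (0.05 log units; that floor lies within the scatter), open at one end because the limit of > 50000 nM in this assay, at which 2 of the 3 values shown sit, bounds it. Compound 4 `CSc1ccccc1C(=O)Nc1sc2c(c1C(N)=O)CCN(C(=S)Nc1ccccc1Cl)C2` carries methylsulfanyl in place of methoxy on an aromatic carbon, the same change at the same kind of place. The step from compound 3 to compound 4 is expected to be a number no higher from compound 3 to compound 4 (the limit leaves the size open), since the measured one barely moved. Compound 4 is expected at 50000 nM, between 20000 nM and 150000 nM, with a good chance that only a limit is reported.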

Compound 4, half-maximal inhibitory concentration: 34700 nM
Estimate against measurement, compound 4: 1.4-fold (0.16 log units) above, within the range that was stated.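

In this assay, methylsulfanyl in place of methoxy on the core of compound 3 gives an at least 1.4-fold lower number from compound 3 to compound 4 (0.15 log units; that floor lies within the scatter). Set beside the earlier step, the change cannot be told apart between the two cores: the same change on two cores in this assay, an at least 1.1-fold lower number (0.05 log units; that floor lies within the scatter) from compound 1 to compound 2 and an at least 1.4-fold lower number (0.15 log units; that floor lies within the scatter) from compound 3 to compound 4; the limit leaves it open whether they differ. Nothing here shows a real gain on either core, or that the change carries over with a fixed size, since each step starts from a limit and not from a number: the limit of > 50000 nM in this assay, at which 2 of the 4 values shown sit.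

The compounds shown leave open what other groups would do in this place, such as an amine or a longer chain like ethylsulfanyl. Also open, as far as these compounds go, is whether either core can give much stronger inhibition, since compound 4 still sits at 34700 nM.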